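From 2,4-dimethoxyphenyl to 3-chloro-4-fluorophenyl

This account rests on a few compounds, and the source may have more. Where it says the series, first, only, none or still open, it means among the compounds named here.

In a functional assay on K562 cells (Homo sapiens) for antiproliferative activity, with a stated time of 72 h (a higher number here means a weaker inhibitor, a lower number a stronger inhibitor), compound 1 `COc1cccc(CNc2ncnc3c2ncn3[C@@H]2O[C@H](CO)[C@@H](O)[C@H]2O)c1OC` gives > 166000 nM, which is a limit. Compound 2 `COc1ccc(CNc2ncnc3c2ncn3[C@@H]2O[C@H](CO)[C@@H](O)[C@H]2O)c(OC)c1` gives > 166000 nM, also a limit. Compound 2 thus stands at the limit of > 166000 nM in this assay, at which 2 of the 2 values shown sit, with no number to start from.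

Compound 3 `OC[C@H]1O[C@@H](n2cnc3c(NCc4ccc(F)c(Cl)c4)ncnc32)[C@H](O)[C@@H]1O` has 3-chloro-4-fluorophenyl in place of 2,4-dimethoxyphenyl on a saturated chain carbon bound to a nitrogen on an aromatic ring.

Among the measured compounds shown here, the only measured step that bears on this is a step that the two limits leave unreadable from compound 1 to compound 2. It has no readable size and exchanges one dimethoxyphenyl group for another, so it sets no scale for the new group. A shift towards stronger inhibition in this assay is expected, though only tentatively, and another limit remains possible. The estimated change is an at least 5.5-fold lower number from compound 2 to compound 3 (0.74 log units; beyond the scatter). For compound 3 the expected value is 30000 nM, with an estimated range of 3000 nM to 166000 nM.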

Compound 3, half-maximal inhibitory concentration: 5500 nM
Estimate against measurement, compound 3: 5.5-fold (0.74 log units) above; the measured number falls inside the stated range.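

In this assay compound 3 gives 5500 nM, so this position on the shared core can yield a measured number. Putting 3-chloro-4-fluorophenyl in place of either dimethoxyphenyl group gives a large step, an at least 30-fold lower number from compound 2 to compound 3 (1.47 log units; beyond the scatter) and an at least 30-fold lower number from compound 1 to compound 3 (1.47 log units; beyond the scatter), whereas the step between the two dimethoxyphenyl compounds cannot be read. Compound 3 is the only compound shown that stands off the limit: the limit of > 166000 nM in this assay, at which 2 of the 3 values shown sit.

The change removes both methoxy groups and brings in chlorine and fluorine in a single step, so the compounds shown do not separate the contribution of each. How a plain phenyl, a 3-chlorophenyl or a 4-fluorophenyl group would read in this place remains open, and so does any cause of the step.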